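The source may report more compounds than this note shows. Statements on the series, on what has been measured and on what is new or still open speak of the compounds shown alone.

Three compounds share one core and differ in two places. Compound 1 `CC(C)CCn1c(N2CCN(C)CC2)nc2ccccc21` carries an isopropyl group on the chain attached to the aromatic nitrogen; in a functional assay on ileum for inhibition of histamine H1 receptor (Cavia porcellus) (a higher number here means a weaker inhibitor, a lower number a stronger inhibitor), compound 1 gives 1400 nM. Compound 2 `CCCCOCCn1c(N2CCN(C)CC2)nc2ccccc21` instead carries a butoxy group there, and in this assay compound 2 gives 38 nM. Compound 3 `CCCCOCCn1c(N2CCCN(C)CC2)nc2ccccc21` keeps that chain but has 4-methyl-1,4-diazepan-1-yl in place of 4-methylpiperazin-1-yl, and compound 3 gives 10 nM. Among these three numbers compound 2 stands second highest: the step of a 37-fold lower number from compound 1 to compound 2 (1.57 log units; beyond the scatter) was large, while the step of a 3.8-fold lower number from compound 2 to compound 3 (0.58 log units; beyond the scatter) was modest.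

Compound 4 `CCCSCn1c(N2CCN(C)CC2)nc2ccccc21` is not yet measured. It differs from compound 2 in the chain on the aromatic nitrogen: propylsulfanyl in place of butoxymethyl on a saturated chain carbon bound to an aromatic nitrogen. Within the data shown here, the only measured step touching this chain, a 37-fold lower number from compound 1 to compound 2 (1.57 log units; beyond the scatter), shows that the chain strongly shapes the result, so a change here cannot be assumed to be neutral. The entering propylsulfanyl group is shorter than the leaving butoxymethyl group and sits one bond closer to the aromatic nitrogen, which moves compound 4 partway back toward the shape of compound 1. A step beyond the scatter toward a higher number is therefore expected, a 3.9-fold higher number from compound 2 to compound 4 (0.60 log units; beyond the scatter), though smaller than the step from compound 1 to compound 2. For compound 4 the expected value is 150 nM, with a range from 40 nM to 600 nM.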

Compound 4, half-maximal inhibitory concentration: 68 nM
For compound 4 the middle estimate is 2.2-fold (0.34 log units) above the measured one; measured number inside the range.
By their numbers in this assay, from the lowest: compound 3; then compounds 2 and 4 (each within the scatter of the next); then compound 1.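

In this assay, the step of a 1.8-fold higher number from compound 2 to compound 4 (0.25 log units; within the scatter) means the two chains cannot be told apart, even though propylsulfanyl, with 4 heavy atoms, replaces butoxymethyl, with 6 heavy atoms, and sulfur stands where oxygen stood. The step of a 21-fold lower number from compound 1 to compound 4 (1.31 log units; beyond the scatter) then shows that the large difference seen in a 37-fold lower number from compound 1 to compound 2 (1.57 log units; beyond the scatter) is not tied to the butoxy group, since a shorter chain holding sulfur also lies far from compound 1 in the same direction. Among these three chains, the two holding oxygen or sulfur both give much lower numbers than the all-carbon chain of compound 1, but nothing measured here explains why.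

Because chain length and the oxygen-to-sulfur swap change together between compound 2 and compound 4, the compounds shown cannot separate the two, and they leave open how a chain ending in an amine or a carboxylic acid would behave at this position. They also leave open whether the step of a 3.8-fold lower number from compound 2 to compound 3 (0.58 log units; beyond the scatter), which swaps 4-methylpiperazin-1-yl for 4-methyl-1,4-diazepan-1-yl, would repeat on the shared core with the propylsulfanyl chain in place.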